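2-Hydroxy-1-(hydroxymethyl)ethyl in Place of Benzyl: Expected Cytotoxicity

The source may report more compounds than this note shows. Statements on the series, on what has been measured and on what is new or still open speak of the compounds shown alone.

Compound 1, `NC(=S)c1cn(COCc2ccccc2)c2ncnc(N)c12`, > 100000 nM
Compound 2, `COCCOCn1cc(C#N)c2c(N)ncnc21`, > 100000 nM
Compound 3, `Cc1ccc(Cn2cc(C(N)=O)c3c(N)ncnc32)cc1`, > 100000 nM

In a functional assay on KB cells (Homo sapiens) for cytotoxicity (a lower number here means a stronger inhibitor, a higher number a weaker inhibitor), compound 1 gives > 100000 nM, which is a limit of the assay rather than a number. Compound 2 likewise reaches only > 100000 nM, again a limit. Compound 3 stands at > 100000 nM, also a limit. Compound 1 therefore stands exactly where the other two stand: at the limit of > 100000 nM in this assay, at which 3 of the 3 values shown sit. Within the data shown here, no pair of measured compounds differs in a single place, so nothing measured here tells how large a change of this kind moves the read-out, nor in which direction.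

Compound 4, `NC(=S)c1cn(COC(CO)CO)c2ncnc(N)c12`, differs from compound 1 in one place: 2-hydroxy-1-(hydroxymethyl)ethyl in place of benzyl on an oxygen on a saturated carbon. The three measured compounds carry three different groups on the same core, and all three sit at the limit, so the shared core with its varied substituents has given no measurable cytotoxicity so far. The step is estimated as a number no higher from compound 1 to compound 4 (the limit leaves the size open), meaning no movement beyond the scatter is expected. Compound 4 is expected to give 100000 nM, with a range from 30000 nM to 300000 nM, because of the limit of > 100000 nM in this assay, at which 3 of the 3 values shown sit. The most likely outcome for compound 4 is that this assay again reports only a limit and no number.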

Compound 4, half-maximal inhibitory concentration: > 100000 nM
Compound 4: only a limit was reported; the forecaster's own chance of this, stated with the estimate: 85%; the middle value sits exactly at the limit.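

In this assay compound 4 gives > 100000 nM, which is a limit of the assay and not a number. Compound 1 also stands at a limit, so the step from compound 1 to compound 4 cannot be read. The compounds shown leave open whether any group on the shared core gives a readable number in this assay: the limit of > 100000 nM in this assay, at which 4 of the 4 values shown sit.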